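This account rests on a few compounds, and the source may have more. Where it says the series, first, only, none or still open, it means among the compounds named here.

Compound 3 `Cc1noc(C)c1-c1cnc(N)c(Oc2ccc(C(=O)Nc3cccc(Cl)c3)cc2)n1` gives 1340 nM in a functional assay on HeLa cells (Homo sapiens) for inhibition, read by MTT assay, with a stated time of 72 h (on this read-out lower numbers stand for stronger inhibition and higher numbers for weaker inhibition), and sits at the low end of the three numbers shown: compound 1 `Cc1noc(C)c1-c1cnc(N)c(Oc2ccc(C(=O)NC3CC3)cc2)n1` gives 17800 nM, a gap of a 13-fold lower number from compound 1 to compound 3 (1.12 log units; beyond the scatter), while compound 2 `Cc1noc(C)c1-c1cnc(N)c(Oc2ccc(C(=O)Nc3ccc(Cl)cc3)cc2)n1` gives 2230 nM, a gap of only a 1.7-fold lower number from compound 2 to compound 3 (0.22 log units; within the scatter), within the scatter. Compound 4 `Cc1noc(C)c1-c1cnc(N)c(Oc2ccc(C(=O)Nc3ccc(Cl)cn3)cc2)n1` differs from compound 3 by 5-chloropyridin-2-yl in place of 3-chlorophenyl on an amide-type nitrogen. Among the measured compounds shown here, no measured step exchanges a carbon-only ring for one with a hetero atom; the nearest guidance is a 1.7-fold lower number from compound 2 to compound 3 (0.22 log units; within the scatter), where moving the chlorine within the ring changed little, and an 8.0-fold lower number from compound 1 to compound 2 (0.90 log units; beyond the scatter), where the aryl amide clearly beat cyclopropyl. Compound 4 is therefore expected to stay within the scatter, a step of a 1.5-fold higher number from compound 3 to compound 4 (0.17 log units; within the scatter), with an estimated 2000 nM ranging from 700 nM to 6000 nM.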

Compound 4, half-maximal inhibitory concentration: 19200 nM
For compound 4 the middle estimate is 9.6-fold (0.98 log units) below the measured one, outside the stated range (above it).
By their numbers in this assay, from the lowest: compounds 3 and 2 (each within the scatter of the next); then compounds 1 and 4 (each within the scatter of the next).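

In this assay the ring on the amide-type nitrogen matters far more than the earlier shift of the chlorine suggested: 5-chloropyridin-2-yl in place of 3-chlorophenyl gives a 14-fold higher number from compound 3 to compound 4 (1.16 log units; beyond the scatter) and in place of 4-chlorophenyl gives an 8.6-fold higher number from compound 2 to compound 4 (0.93 log units; beyond the scatter) at the same place. The gain of the chlorophenyl amides over cyclopropyl is not kept, with a 1.1-fold higher number from compound 1 to compound 4 (0.03 log units; within the scatter) lying within the scatter. No measurement given here accounts for this loss. On these data alone, whether it belongs to the ring nitrogen itself or to the chlorine's place on the ring stays open, as does how an amine or a carboxylic acid in place of the chlorine would read.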